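The compounds below may be only part of what the source reports. "The series", "measured", "known", "first", "only" and "open" are said of these compounds alone.

For the measured compounds named here, compound 1 `Fc1cc(F)cc(-c2nc(N3CCN(c4ncccc4C(F)(F)F)CC3)[nH]c2-c2ccc(C(F)(F)F)cc2)c1` is one of two compounds so far measured in a functional assay on CHO cells for antagonist activity at transient receptor potential cation channel subfamily V member 1 (Rattus norvegicus), read by calcium flux; a lower number here means a stronger inhibitor, a higher number a weaker inhibitor; in this assay compound 1 gives 35 nM, the lower of the two numbers. Compound 2 `OCc1cnc(N2CCN(c3nc(-c4ccccc4)c(-c4ccc(C(F)(F)F)cc4)[nH]3)CC2)c(Cl)c1` gives 90 nM in this assay, and the gap between the two lies beyond the usual scatter of repeated measurements. Compound 3 `FC(F)(F)c1ccc(-c2[nH]c(N3CCN(c4ncccc4C(F)(F)F)CC3)nc2Cl)cc1` has not yet been measured. It is built from compound 1 by a single change: chloro in place of 3,5-difluorophenyl on an aromatic carbon. Going by the values given here, a large group gives way to a single atom on the shared core, and no measured pair shows such a swap, so there is no recorded step to lean on. The expectation is a moderate loss of inhibitory strength, because compound 1 sits at 35 nM with the larger group still in place. The expected step is a 3.1-fold higher number from compound 1 to compound 3 (0.50 log units; beyond the scatter). Compound 3 is therefore estimated at 110 nM in this assay, within a range from 30 nM to 400 nM.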

Compound 3, half-maximal inhibitory concentration: 160 nM
Beside the measured number, compound 3's estimate is 1.5-fold (0.16 log units) below it, within the range that was stated.
By their numbers in this assay, from the lowest: compound 1; then compounds 2 and 3 (each within the scatter of the next).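

For the compounds shown here, at this position on the shared core, chloro in place of 3,5-difluorophenyl gives a 4.6-fold higher number from compound 1 to compound 3 (0.66 log units; beyond the scatter) in this assay, the first recorded step for this swap. The step is modest for the removal of a whole ring: with only a single atom on that aromatic carbon, compound 3 still gives 160 nM, so the 3,5-difluorophenyl group is not required for inhibition in this series. Nothing on record explains why the number rises.

The compounds shown leave open whether the rise in number follows from losing the ring, losing the fluorines, or gaining the chlorine. Hydrogen, methyl, an amine or a small ring such as cyclopropyl at this same carbon could help separate these possibilities.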